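Chain extension of the acid on compound 1: expectation

A few compounds are considered here, and "the series" means these few. Any claim that something is new, unique, unknown or untested is made for them only; others in the source may bear on it.

Measured so far:
compound 1 `O=C(O)CCC(=O)N1N=C(c2c(-c3ccccc3)c3cc(Cl)ccc3[nH]c2=O)CC1c1ccc(Br)cc1` gives 3100 nM
compound 2 `O=C(O)CCC(=O)N1N=C(c2c(-c3ccccc3)c3cc(Cl)ccc3[nH]c2=O)CC1c1ccc([N+](=O)[O-])cc1` gives 1100 nM

In an assay on cells (Oocyte) for negative allosteric modulation of glutamate receptor ionotropic, NMDA 2D (Rattus norvegicus), read by two-electrode voltage clamp (a higher number here means a weaker inhibitor, a lower number a stronger inhibitor), compound 1 stands highest of the two numbers, with compound 2 the nearer one. Among the compounds with values here, the single measured step, a 2.8-fold lower number from compound 1 to compound 2 (0.45 log units; beyond the scatter), changes a substituent on an aromatic carbon and leaves the rest of the shared core untouched. Compound 3 `O=C(O)CCCC(=O)N1N=C(c2c(-c3ccccc3)c3cc(Cl)ccc3[nH]c2=O)CC1c1ccc(Br)cc1` differs from compound 1 by carboxymethyl in place of carboxy on a saturated chain carbon, two bonds along the chain from a carbonyl carbon. Within the data shown here, no measured step bears on this change, so nothing in the data points either way. The expected step is a 1.0-fold lower number from compound 1 to compound 3 (0.01 log units; within the scatter), none beyond the scatter. Compound 3 is estimated at 3000 nM in this assay, with a range of 1200 nM to 8000 nM.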

Compound 3, half-maximal inhibitory concentration: 4000 nM
For compound 3 the middle estimate is 1.3-fold (0.12 log units) below the measured one; the range from low to high includes it.
By their numbers in this assay, from the lowest: compound 2; then compounds 1 and 3 (each within the scatter of the next).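

In this assay, the acid chain takes one more carbon, (3-carboxypropyl)carbonyl in place of (2-carboxyethyl)carbonyl, with a 1.3-fold higher number from compound 1 to compound 3 (0.11 log units; within the scatter), so this position accepts the extension without a difference beyond the scatter. Within the data shown here, the earlier step reported only on the aromatic substituent, so this is the first reading on the acid chain. No available evidence bears on this result.

Open, from the compounds shown here alone, is whether a still longer chain, or a primary amide in place of the carboxylic acid, keeps this level. Also open, going by these compounds, is whether nitro in place of bromo gives a similar step on the longer chain.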